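Compound 4 Without a Drawn Configuration Beside Compound 3

This account rests on a few compounds, and the source may have more. Where it says the series, first, only, none or still open, it means among the compounds named here.

In an in vitro functional assay on Sf9 cells for agonist activity at histamine H2 receptor (Homo sapiens), read by GTPgammaS binding (a higher number here means that more compound is needed for the effect, a lower number that less compound is needed), compound 1 `Cc1nc(N)sc1CCCNC(=N)NC(=O)C[C@@H](C)c1ccccc1` gives 53.7 nM. Compound 2 `Cc1nc(N)sc1CCCNC(=N)NC(=O)C[C@H](C)C1CCCCC1` gives 28.8 nM in this assay, and compound 3 `Cc1nc(N)sc1CCCNC(=N)NC(=O)C[C@@H](C)C1CCCCC1` gives 20.4 nM. Compound 3 thus stands at the low end of the three numbers: the step of a 2.6-fold lower number from compound 1 to compound 3 (0.42 log units; beyond the scatter) lies beyond the scatter, whereas the step of a 1.4-fold lower number from compound 2 to compound 3 (0.15 log units; within the scatter) lies within it, the two compounds being separated only by the fact that one of compounds 2 and 3 is drawn with a defined configuration and the other without, at the place where they differ.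

Compound 4 `Cc1nc(N)sc1CCCNC(=N)NC(=O)CC(C)C1CCCCC1` differs from compound 3 by the two compounds have the same atoms and bonds; at least one stereo element is drawn with a configuration in one of them and without one in the other: 1 of 2 stereo elements differ; a stereocentre at a saturated chain carbon is drawn R in compound 3 and without a configuration in compound 4. The step that bears on this change is the step from compound 2 to compound 3, with the configuration at that saturated chain carbon drawn the other way, and it stayed within the scatter. The steps of a 1.9-fold lower number from compound 1 to compound 2 (0.27 log units; within the scatter) and a 2.6-fold lower number from compound 1 to compound 3 (0.42 log units; beyond the scatter) show that either drawn configuration on the cyclohexyl bearing chain sits close to the same number. No step beyond the scatter is therefore expected in this assay from compound 3 to compound 4, and the expected step of a 1.2-fold higher number from compound 3 to compound 4 (0.07 log units; within the scatter) is small. Compound 4 is estimated at 24 nM, with a range from 14 nM to 42 nM.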

Compound 4, half-maximal effective concentration: 9.33 nM
For compound 4 the middle estimate is 2.6-fold (0.41 log units) above the measured one; measured number below the stated range.
By their numbers in this assay, from the lowest: compound 4; then compounds 3, 2 and 1 (each within the scatter of the next, the first and the last beyond it).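

In this assay, the stereocentre at this saturated chain carbon now gives steps beyond the scatter: a 2.2-fold lower number from compound 3 to compound 4 (0.34 log units; beyond the scatter) and a 3.1-fold lower number from compound 2 to compound 4 (0.49 log units; beyond the scatter), although a 1.4-fold lower number from compound 2 to compound 3 (0.15 log units; within the scatter) stays within it. With a 5.8-fold lower number from compound 1 to compound 4 (0.76 log units; beyond the scatter) as well, compound 4 has the lowest number of the four, so the cyclohexyl compounds no longer all sit close together. Compounds 2, 3 and 4 share the same atoms and bonds, and what separates compound 3 from compound 4 is only this: the fact that one of compounds 3 and 4 is drawn with a defined configuration and the other without, at the place where they differ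

What the undrawn stereocentre of compound 4 stands for in the sample remains open, so the drawing alone does not account for the lower number. Also open, from the compounds shown here alone, is how a cyclopentyl group or a longer chain in place of the cyclohexyl would read in this assay.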